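The compounds below may be only part of what the source reports. "The series", "measured", "known", "first", "only" and "open" are said of these compounds alone.

Within the data shown here, compound 3 `Nc1cc(N)c2nc(-c3ccccc3)c(Oc3ccc(F)cc3)nc2c1` is the one member of the series with a number in a functional assay on HOP-92 cells (Homo sapiens) for inhibition, read by sulforhodamine B assay, with a stated time of 48 h; on this read-out lower numbers stand for higher toxicity in this test and higher numbers for lower toxicity in this test: compound 3 gives 72400 nM. Compound 1 `CCOC(=O)[C@H](CCC(=O)O)NC(=O)c1ccc(Oc2nc3cc(N)cc(N)c3nc2-c2ccccc2)cc1` stands in this assay at a limit, < 100000 nM. Compound 2 `Nc1cc(N)c2nc(-c3ccccc3)c(NCc3ccc(F)cc3)nc2c1` also stands in this assay at a limit, < 100000 nM. The step that the limit leaves unreadable from compound 2 to compound 3 cannot be sized because the limit of < 100000 nM in this assay, at which 2 of the 3 values shown sit, masks one end of it. Compound 4 `Nc1cc(N)c2nc(-c3ccccc3)c(Sc3ccc(F)cc3)nc2c1` remains to be measured; it differs from compound 3 in that ((4-fluorophenyl)sulfanyl in place of 4-fluorophenoxy on an aromatic carbon). Among the measured compounds shown here, no measured step covers an exchange of this kind, and no step in the set is readable at all, so nothing here argues for a move beyond the scatter. The step of a 1.0-fold lower number from compound 3 to compound 4 (0.01 log units; within the scatter) is expected to stay within the scatter. For compound 4 the estimate in this assay is 70000 nM, between 25000 nM and 160000 nM.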

Compound 4, concentration lethal to 50% of the cells: < 100000 nM
Compound 4 ended at the assay's limit (the forecaster's own chance of this, stated with the estimate: 35%); the middle value is on the limit's open side.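

The steps from compound 3 to compound 4 and from compound 2 to compound 4 cannot be read in this assay, because both end at a limit: the limit of < 100000 nM in this assay, at which 3 of the 4 values shown sit.

From the compounds shown here alone, whether (4-fluorophenyl)sulfanyl truly differs from 4-fluorophenoxy or (4-fluorobenzyl)amino on the shared core stays open.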